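Series notes: pyridinesulfonamide alkynes in cell growth assay

A few compounds are considered here, and "the series" means these few. Any claim that something is new, unique, unknown or untested is made for them only; others in the source may bear on it.

Compound 1 `O=S(=O)(Nc1ccc(F)c(C#Cc2cnc3[nH]ccc3c2)c1F)c1cccnc1` — > 10000 nM
Compound 2 `Cc1n[nH]c2ncc(C#Cc3c(F)ccc(NS(=O)(=O)c4cccnc4)c3F)cc12` — 4630 nM

Compound 1 `O=S(=O)(Nc1ccc(F)c(C#Cc2cnc3[nH]ccc3c2)c1F)c1cccnc1` returns only a limit in a functional assay on HCT-116 cells (Homo sapiens) for antiproliferative activity, read by MTT assay, with a stated time of 68 h (a lower number here means a stronger inhibitor, a higher number a weaker inhibitor), at > 10000 nM. Going by the values given here, compound 2 `Cc1n[nH]c2ncc(C#Cc3c(F)ccc(NS(=O)(=O)c4cccnc4)c3F)cc12` gives 4630 nM in this assay, the only real number of the set. The step of an at least 2.1-fold lower number from compound 1 to compound 2 (0.33 log units; beyond the scatter) rests on a limit, as stated in the limit of > 10000 nM in this assay, at which 1 of the 2 values shown sits, so only its lower bound is known.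

Compound 3 `O=S(=O)(Nc1ccc(F)c(C#Cc2cnc3[nH]nc(-c4cccc(Cl)c4)c3c2)c1F)c1cccnc1` differs from compound 2 by 3-chlorophenyl in place of methyl on an aromatic carbon. Among the compounds with values here, the one measured step concerns an exchange of the whole fused ring attached to the triple-bonded carbon, not a substituent on an aromatic carbon of the five-membered aromatic ring with 2 nitrogen, so no measured step bears directly on this change. With nothing to anchor the direction, the expectation for compound 3 is a step of roughly a 1.9-fold lower number from compound 2 to compound 3 (0.27 log units; within the scatter), which may fall inside the scatter. Compound 3 is therefore expected near 2500 nM, between 500 nM and 10000 nM.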

Compound 3, half-maximal inhibitory concentration: > 10000 nM
Compound 3 ended at the assay's limit; the forecaster's own chance of this, stated with the estimate: 20%; middle value at least 4.0-fold (0.60 log units) away from the limit.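

At this aromatic carbon of the five-membered aromatic ring with 2 nitrogen, 3-chlorophenyl in place of methyl gives an at least 2.1-fold higher number from compound 2 to compound 3 (0.33 log units; beyond the scatter), the first measured read on this position, and it shows that the position is not indifferent to the change in this assay: the exchange of this one group costs the measurable activity of compound 2. Compound 3 gives > 10000 nM, which is a limit of the assay and not a number. The true size of the step therefore remains unknown, only its lower bound can be read, and compound 2 stays the one compound in the set with a real number, so the values give no finer ranking: the limit of > 10000 nM in this assay, at which 2 of the 3 values shown sit.

As far as these compounds go, what remains open is whether the loss follows from the phenyl ring itself or from its chlorine, which unsubstituted phenyl at the same carbon would separate. From the compounds shown here alone, whether anything at this carbon can improve on methyl is equally open, with ethyl, a methoxy group or an amine as the plainest small groups to compare in this assay.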